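Hydroxy for trifluoromethyl on the amide aniline of compound 3

The compounds below may be only part of what the source reports. "The series", "measured", "known", "first", "only" and "open" are said of these compounds alone.

Compound 3 `O=C(Nc1ccc(C(F)(F)F)cc1)C1NCCc2ccccc21` gives 4220 nM in a functional assay on NUGC-3 cells (Homo sapiens) for inhibition, read by sulforhodamine B assay, with a stated time of 48 h; on this read-out higher numbers stand for weaker inhibition of growth and lower numbers for stronger inhibition of growth. Compound 1 `O=C(Nc1ccc(C(F)(F)F)cc1)C1c2ccccc2CCN1C(=O)c1ccc(Cl)cc1` gives 4200 nM in this assay, and the two differ by a 1.0-fold higher number from compound 1 to compound 3 (0.00 log units; within the scatter), so compound 3 and compound 1 sit together with no separation that the scatter allows. Compound 2 `COc1ccc(NC(=O)C2NCCc3ccccc32)cc1` reaches only the limit of > 10000 nM in this assay. Compound 3 therefore stands at one of the two actual numbers in the series, the remaining entry being a limit (the limit of > 10000 nM in this assay, at which 1 of the 3 values shown sits).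

Compound 4 `O=C(Nc1ccc(O)cc1)C1NCCc2ccccc21` differs from compound 3 by hydroxy in place of trifluoromethyl on an aromatic carbon. For the measured compounds named here, the one measured step that bears on this change is an at least 2.3-fold lower number from compound 2 to compound 3 (0.37 log units; beyond the scatter), where exchanging methoxy for trifluoromethyl on the same aromatic carbon moved the number out of the limit and down. Hydroxy is, like methoxy, a small oxygen substituent at that position, so the reverse direction is the natural expectation: a modest rise in this assay, plausibly back toward or past the limit. Compound 1 shows that the ring nitrogen substituent does not shift the number, which leaves the aromatic substituent as the only lever seen so far.

Compound 4 is expected to give about 9000 nM in this assay, with a plausible range from 4000 nM to 20000 nM. That estimate corresponds to a step of a 2.1-fold higher number from compound 3 to compound 4 (0.33 log units; beyond the scatter).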

Compound 4, concentration for 50% growth inhibition: 4370 nM
The estimate for compound 4 lay 2.1-fold (0.31 log units) above the measured number, and the stated range covers the measured number.
By their numbers in this assay, from the lowest: compounds 1, 3 and 4 (each within the scatter of the next). At a limit, above all of these: compound 2.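

In this assay, the exchange of trifluoromethyl for hydroxy on this aromatic carbon, para to a large group, gives a 1.0-fold higher number from compound 3 to compound 4 (0.02 log units; within the scatter), so these two groups, which differ in heavy atoms and in hydrogen-bond donors and acceptors, are not separated on this read-out. Loss of the methyl from the oxygen gives an at least 2.2-fold lower number from compound 2 to compound 4 (0.35 log units; beyond the scatter), which shows that an oxygen on this carbon does not by itself go with weak inhibition of growth: compound 4 goes against the reading suggested by compound 2 alone, and the separation within this set rests on that methyl. The reading of that step is one-sided, as compound 2 stands at a limit and not at a number: the limit of > 10000 nM in this assay, at which 1 of the 4 values shown sits.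

The compounds shown do not tell how an amine, a carboxylic acid or a plain hydrogen on the same aromatic carbon would read, nor whether a longer chain on the oxygen would behave as methoxy does. They also leave open whether hydroxy on this carbon would still match trifluoromethyl with (4-chlorophenyl)carbonyl on the ring nitrogen, and what underlies the match between compound 3 and compound 4.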